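The compounds below may be only part of what the source reports. "The series", "measured", "known", "first", "only" and "open" are said of these compounds alone.

Compound 2 `Cc1ccc(F)cc1-c1cccc(COc2ccc([C@H](CC(=O)O)c3nccn3C)cc2)c1` gives 36 nM in an assay on CHO cells for agonist activity at Free fatty acid receptor 1 (Homo sapiens), read by luminescence, with a stated time of 20 s, in the presence of a further agent that is not named here (on this read-out higher numbers stand for an effect only at larger amounts of compound and lower numbers for an effect already at smaller amounts), and compound 1 `Cn1ccnc1[C@@H](CC(=O)O)c1ccc(OCc2cccc(-c3ccc(Cl)cc3Cl)c2)cc1` gives 69 nM; the two sit within the scatter of each other, as the step of a 1.9-fold lower number from compound 1 to compound 2 (0.28 log units; within the scatter) shows. Compound 3 `Cc1cc(F)ccc1-c1cccc(COc2ccc([C@H](CC(=O)O)c3nccn3C)cc2)c1` differs from compound 2 only by 4-fluoro-2-methylphenyl in place of 5-fluoro-2-methylphenyl on an aromatic carbon. Going by the values given here, the one measured step that bears on this group, from compound 1 to compound 2, changed the same aryl group and stayed within the scatter. A further change of that group is therefore expected to give no step beyond the scatter, which is what a 1.1-fold higher number from compound 2 to compound 3 (0.05 log units; within the scatter) means. Compound 3 is estimated at 40 nM, within a range from 15 nM to 110 nM.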

Compound 3, half-maximal effective concentration: 59 nM
Compound 3: the middle estimate sits 1.5-fold (0.17 log units) below what was measured; the measured number falls inside the stated range.
By their numbers in this assay, from the lowest: compounds 2, 3 and 1 (each within the scatter of the next).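

Exchanging 5-fluoro-2-methylphenyl for 4-fluoro-2-methylphenyl, two groups with the same atoms joined differently, gives in this assay a 1.6-fold higher number from compound 2 to compound 3 (0.21 log units; within the scatter) and so no change that can be read. Exchanging 2,4-dichlorophenyl for 4-fluoro-2-methylphenyl gives a 1.2-fold lower number from compound 1 to compound 3 (0.07 log units; within the scatter) and also stays within the scatter, so all three aryl groups at this position read alike. Nothing available here offers an explanation for this.

The compounds shown leave open whether an aryl group bearing an amine or a methoxy group would give a step beyond the scatter. They also leave open whether the same would hold on a changed core.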